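Adding a second methoxy to the aryl ring of compound 1

This account rests on a few compounds, and the source may have more. Where it says the series, first, only, none or still open, it means among the compounds named here.

Measured compounds:
Compound 1, `COc1ccc(-c2cc(/C=C/C(=O)c3ccc(N)cc3)[nH]n2)cc1`: 2320 nM
Compound 2, `COc1ccc(C(=O)/C=C/c2cc(-c3cc(OC)c(OC)c(OC)c3)n[nH]2)cc1`: 2670 nM

The two measured compounds were tested in a functional assay on MOLT-4 cells (Homo sapiens) for inhibition, read by sulforhodamine B assay, with a stated time of 48 h; a lower number here means a stronger inhibitor of growth, a higher number a weaker inhibitor of growth. In this assay compound 1 gives 2320 nM, and compound 2 gives 2670 nM. Compound 1 has the lowest of the two numbers, but its nearest neighbour, compound 2, sits within the scatter of repeated measurements, so the two values show no difference that can be read as a real one.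

Compound 3, `COc1ccc(-c2cc(/C=C/C(=O)c3ccc(N)cc3)[nH]n2)cc1OC`, has not yet been measured in this assay. It differs from compound 1 in a single place: methoxy in place of hydrogen on an aromatic carbon. For the measured compounds named here, no step between measured compounds isolates such a change, so the expectation rests on what the two measured values show. Compound 2, which carries three methoxy groups on its aryl ring, gives a number close to that of compound 1, and this suggests that adding one more methoxy group leaves the number much where it is.

Compound 3 is therefore estimated at 2100 nM, with a range of 900 nM to 4800 nM. The step expected from compound 1 to compound 3 in this assay is a 1.1-fold lower number from compound 1 to compound 3 (0.04 log units; within the scatter), which is no step beyond the scatter.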

Compound 3, concentration for 50% growth inhibition: 3110 nM
For compound 3 the middle estimate is 1.5-fold (0.17 log units) below the measured one; the measured number falls inside the stated range.
By their numbers in this assay, from the lowest: compounds 1, 2 and 3 (each within the scatter of the next).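

In this assay, methoxy in place of hydrogen on an aromatic carbon, ortho to a methoxy group and meta to a large group, gives a 1.3-fold higher number from compound 1 to compound 3 (0.13 log units; within the scatter). For the compounds shown here, this is the first reading of this single change, and it shows that this carbon of the core of compound 1 can carry a methoxy group with no difference that can be read as a real one, something the comparison of compound 1 with compound 2 could not isolate, as those two differ in more than one place. Nothing available here accounts for this outcome.

The compounds shown leave open whether a hydroxy group, an ethoxy group or a fluorine atom on this same carbon would also stay within the scatter of compound 1, or whether a longer chain such as benzyloxy would move the number beyond it. From the compounds shown here alone, they also leave open what hydrogen in place of the methoxy group already present in compound 1 would give, so the contribution of that first methoxy group remains unknown.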